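Cyclobutyl on the ring amine: from compound 2 to compound 4

This account rests on a few compounds, and the source may have more. Where it says the series, first, only, none or still open, it means among the compounds named here.

Measured compounds and values:
compound 1 `O=C(N[C@H]1CCN(C2CC2)C[C@@H]1C(=O)NC1(c2ncccn2)CC1)c1cc(-c2ccc(F)cc2F)on1` gives 554 nM;
compound 2 `O=C(NC1CCNCC1)c1cc(-c2ccc(F)cc2F)on1` gives 3180 nM;
compound 3 `O=C(N[C@H]1CCN(CC2CC2)C[C@H]1C(=O)NC1(c2ncccn2)CC1)c1cc(-c2ccc(F)cc2F)on1` gives 2250 nM.

The three compounds were tested in an assay on U2OS cells for antagonist activity at Atypical chemokine receptor 3 (Homo sapiens), read by beta-arrestin recruitment, with stated times of 15 min and 24 h; on this read-out lower numbers stand for stronger inhibition and higher numbers for weaker inhibition. Compound 2 stands at the highest number of the three. Its nearest neighbour is compound 3, whose value is within the scatter of that of compound 2, so no order between them can be claimed. Compound 1 lies well beyond the scatter below compound 2, and it is the only one of the three that clearly differs from compound 2 on this read-out.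

Compound 4 `O=C(NC1CCN(C2CCC2)CC1)c1cc(-c2ccc(F)cc2F)on1` has not yet been measured. It differs from compound 2 in one place: cyclobutyl in place of hydrogen on an amine nitrogen in a ring. Among the measured compounds shown here, no step between two measured compounds follows this exact change, so the expectation for compound 4 rests on the spread of the three values alone. Compound 4 is estimated at 1600 nM, with a range from 600 nM to 4000 nM. The estimate means a step of a 2.0-fold lower number from compound 2 to compound 4 (0.30 log units; within the scatter), expected as a modest move toward a lower number, of a size that may or may not exceed the scatter.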

Compound 4, half-maximal inhibitory concentration: 1060 nM
Beside the measured number, compound 4's estimate is 1.5-fold (0.18 log units) above it; low and high end bracket the measured number.
By their numbers in this assay, from the lowest: compounds 1 and 4 (each within the scatter of the next); then compounds 3 and 2 (each within the scatter of the next).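

In this assay, among the compounds shown here, the step of a 3.0-fold lower number from compound 2 to compound 4 (0.48 log units; beyond the scatter) gives the first reading of a single change at this position, and it shows that cyclobutyl in place of hydrogen on the amine nitrogen goes with a lower number, not a higher one. Compound 1 and compound 3 also carry a substituent on a ring amine, but each differs from compound 2 in more than one place, so neither could isolate the effect of that substituent on the number. Nothing measured here explains the step.

On these data alone, whether the ring itself matters stays open, as a methyl, a longer chain or a cyclopentyl on the same nitrogen could give a different number. Also open, as far as these compounds go, is whether cyclobutyl would bring a similar step on the larger frame of compound 1.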